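One Group Exchanged on a Sulfonamide Nitrogen

The source may report more compounds than this note shows. Statements on the series, on what has been measured and on what is new or still open speak of the compounds shown alone.

Compound 1 `O=C(/C=C/c1cccnc1)NCCCCCc1cccc(S(=O)(=O)Nc2ccccc2)c1`: 105 nM
Compound 2 `Cc1ccc(C)c(NS(=O)(=O)c2cccc(CCCCCCNC(=O)/C=C/c3cccnc3)c2)c1`: 22.6 nM

In a functional assay on HeLa cells (Homo sapiens) for inhibition, read by CCK-8 assay, with a stated time of 72 h (a lower number here means a stronger inhibitor, a higher number a weaker inhibitor), compound 2 gives 22.6 nM and holds the lower of the two numbers. Compound 1 gives 105 nM and the gap between the two lies beyond the usual scatter. Within the data shown here, these two compounds differ in more than one place, so the data hold no measured step for a single change.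

Compound 3 `O=C(/C=C/c1cccnc1)NCCCCCCc1cccc(S(=O)(=O)Nc2ccc(C(F)(F)F)cc2)c1` has not yet been measured. Its difference from compound 2 4-(trifluoromethyl)phenyl in place of 2,5-dimethylphenyl on a sulfonamide nitrogen places 4-(trifluoromethyl)phenyl in place of 2,5-dimethylphenyl on a sulfonamide nitrogen. Among the measured compounds shown here, with no measured precedent for this exchange, only a small move toward a weaker number is expected in this assay and it may well stay within the scatter. The starting point for this expectation is compound 2 at 22.6 nM in the same measurement. The estimated change is a 1.3-fold higher number from compound 2 to compound 3 (0.12 log units; within the scatter) and its size remains uncertain. For compound 3 the expected value is 30 nM with an estimated range from 8 nM to 110 nM when the measurement is made.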

Compound 3, half-maximal inhibitory concentration: 1450 nM
The estimate for compound 3 lay 48-fold (1.68 log units) below the measured number; measured number outside the range, above it.
By their numbers in this assay, from the lowest: compound 2; then compound 1; then compound 3.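

Putting 4-(trifluoromethyl)phenyl in place of 2,5-dimethylphenyl on a sulfonamide nitrogen gives, in this assay, a 64-fold higher number from compound 2 to compound 3 (1.81 log units; beyond the scatter), and this is the first measured step for a single change among these compounds. It shows that the group on this nitrogen has a large bearing on the number in this assay, even though the leaving and entering groups each hold one six-membered aromatic ring of carbon only, with no hydrogen-bond donors, no hydrogen-bond acceptors and no net charge. No measurement here bears on why the number rises so far.

The exchange removes two methyl groups and brings in one trifluoromethyl group at a different place in the group's name, so this single step cannot separate the kind of substituent from where it sits on the ring. As far as these compounds go, whether a single methyl, a chlorine atom or an amine on that phenyl ring would stay close to compound 2 or fall nearer compound 3 remains open, as does whether the step keeps its size on a different chain.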